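Swapping the aryl ether for a benzyl group in a weak series

The source may hold more compounds than are shown below. What is called first, only, known or untested is meant among the compounds shown, and "the series" means these compounds.

Compound 2 `CC(C)=CCc1cc(C(=O)Nc2cc3ccc(Oc4ccc(C(C)(C)C)cc4)c(C)c3oc2=O)ccc1O` holds the lowest of the two numbers available in a functional assay on SK-BR-3 cells (Homo sapiens) for antiproliferative activity (a higher number here means a weaker inhibitor, a lower number a stronger inhibitor), giving 68300 nM. Its closest neighbour is compound 1 `CC(=O)Oc1ccc(C(=O)Nc2cc3ccc(Oc4ccc(C(C)(C)C)cc4)c(C)c3oc2=O)cc1CC=C(C)C`, which gives 72400 nM; the step of a 1.1-fold lower number from compound 1 to compound 2 (0.03 log units; within the scatter) is the only measured one, and it concerns a different position. Compound 3 `COc1cccc(Oc2ccc3cc(NC(=O)c4ccc(OC)c(-c5cccc(OC)c5)c4)c(=O)oc3c2C)c1` reaches only a limit in this assay, > 100000 nM. Compound 4 `COc1ccc(Cc2ccc3cc(NC(=O)c4ccc(O)c(CC=C(C)C)c4)c(=O)oc3c2C)cc1` differs from compound 2 by 4-methoxybenzyl in place of 4-(tert-butyl)phenoxy on an aromatic carbon. Going by the values given here, no measured step touches this position, so no direction is anticipated beyond the scatter. For compound 4 the expected value is 70000 nM, within 25000 nM to 200000 nM, with the step of a 1.0-fold higher number from compound 2 to compound 4 (0.01 log units; within the scatter) estimated as small.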

Compound 4, half-maximal inhibitory concentration: 11100 nM
For compound 4 the middle estimate is 6.3-fold (0.80 log units) above the measured one, and the stated range ends above it.
By their numbers in this assay, from the lowest: compound 4; then compounds 2 and 1 (each within the scatter of the next). At a limit, above all of these: compound 3.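

Exchanging 4-(tert-butyl)phenoxy for 4-methoxybenzyl gives a 6.2-fold lower number from compound 2 to compound 4 (0.79 log units; beyond the scatter) in this assay, so this position can move the result beyond the scatter, which the acetyl-to-hydrogen step did not. The link to the core and the substituent on the outer ring change together, so the step cannot be divided between them. Nothing measured here explains the difference. A 4-(tert-butyl)benzyl or a 4-methoxyphenoxy group would help separate those two parts. Going by these compounds, whether an amine or a carboxylic acid on that outer ring would lower the number further remains open.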